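The source may report more compounds than this note shows. Statements on the series, on what has been measured and on what is new or still open speak of the compounds shown alone.

Measured so far in a physicochemical assay for solubility, at pH 7.4; on this read-out lower numbers stand for lower solubility and higher numbers for higher solubility

compound 1 `O=C(/C=C/c1cccc(/C=C/C(=O)c2ccccc2)c1)NO` gives 12000 nM
compound 2 `CN1CCN(c2cccc(C(=O)/C=C/c3cccc(/C=C/C(=O)NO)n3)c2)CC1` gives 380000 nM

Compound 2 holds the higher of the two values (380000 nM) and compound 1 sits lower (12000 nM), a gap beyond the usual scatter. Compound 3 `O=C(/C=C/c1cccc(/C=C/C(=O)c2ccccc2)n1)NO` is not yet measured. Relative to compound 2 it carries hydrogen in place of 4-methylpiperazin-1-yl on an aromatic carbon. For the measured compounds named here, no measured pair isolates this change, so the expectation rests on thin evidence. Compound 1 also lacks the 4-methylpiperazin-1-yl group and gives 12000 nM on its own core, so a clear downward step beyond the scatter is expected in this assay for this change. The expected size is a 13-fold lower number from compound 2 to compound 3 (1.10 log units; beyond the scatter) and remains uncertain. Compound 3 is estimated at 30000 nM (expected range 8000 nM to 120000 nM).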

Compound 3, solubility: 16000 nM
Estimate against measurement, compound 3: 1.9-fold (0.27 log units) above, within the range that was stated.
By their numbers in this assay, from the lowest: compounds 1 and 3 (each within the scatter of the next); then compound 2.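

In this assay, for the compounds shown here, replacing 4-methylpiperazin-1-yl with hydrogen on an aromatic carbon of the ring of carbon only gives a 24-fold lower number from compound 2 to compound 3 (1.38 log units; beyond the scatter) and is the only one-place reading of this change so far. Without the group, compound 3 gives 16000 nM and compound 1 gives 12000 nM and these two values lie within the scatter of each other. The step therefore gives the large gap separating compound 2 from the other two a one-place counterpart, but no measurement on hand accounts for its size.

Still open, on these data alone, is whether the step needs the whole 4-methylpiperazin-1-yl ring or would also appear with a simpler amine such as dimethylamino, or with morpholine, on the same aromatic carbon. A carboxylic acid at that carbon would show whether a step of this size is confined to amines.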